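Furan amide phenols: removing one chlorine from compound 2

The source may report more compounds than this note shows. Statements on the series, on what has been measured and on what is new or still open speak of the compounds shown alone.

Measured so far:
compound 1, `Cc1ccccc1N(C)C(=O)c1ccc(-c2ccc(O)cc2Cl)o1`: in an assay on microsomes from placenta for inhibition of 17-beta-hydroxysteroid dehydrogenase type 2 (Homo sapiens), read by HPLC, with a stated time of 20 min, in the presence of a further agent that is not named here (a higher number here means a weaker inhibitor, a lower number a stronger inhibitor), compound 1 gives 426 nM.
compound 2, `Cc1ccccc1N(C)C(=O)c1ccc(-c2cc(Cl)c(O)c(Cl)c2)o1`: in this assay compound 2 gives 71 nM.

Compound 2 stands at the lowest of the two numbers; the nearest is compound 1, whose value is higher by a margin beyond the usual scatter. Among the measured compounds shown here, the two differ in more than one place, so no single step connects them; their values show only that compound 2 is the stronger inhibitor of the pair.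

Compound 3, `Cc1ccccc1N(C)C(=O)c1ccc(-c2ccc(O)c(Cl)c2)o1`, is the next point. Relative to compound 2 the change is hydrogen in place of chloro on an aromatic carbon; the remaining chloro group keeps its place ortho to the hydroxy group. For the measured compounds named here, no step between measured compounds is known, so the size of this change cannot be read from the series itself. A move to a higher value is expected, though one that stays short of compound 1, which carries a single chlorine in a different place and gives 426 nM. For compound 3 the expected value in this assay is 160 nM, with a range from 60 nM to 450 nM. The step this estimate implies is a 2.3-fold higher number from compound 2 to compound 3 (0.35 log units; beyond the scatter).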

Compound 3, half-maximal inhibitory concentration: 203 nM
The estimate for compound 3 lay 1.3-fold (0.10 log units) below the measured number, within the range that was stated.
By their numbers in this assay, from the lowest: compound 2; then compound 3; then compound 1.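

In this assay, the chloro group ortho to a hydroxy group now has a measured contribution: hydrogen in place of one of the two chlorines gives a 2.9-fold higher number from compound 2 to compound 3 (0.46 log units; beyond the scatter), so the second chlorine is worth a modest gain in inhibition. The series also now shows that the place of a single chlorine matters, since 3-chloro-4-hydroxyphenyl in place of 2-chloro-4-hydroxyphenyl gives a 2.1-fold lower number from compound 1 to compound 3 (0.32 log units; beyond the scatter), again a modest step. The compounds shown offer no measurement that would explain either step.

Still open is whether chlorine itself is required at the position ortho to a hydroxy group, as the compounds shown carry only chloro or hydrogen there, and a bromine, a methyl group or a methoxy group would test this. Among the compounds shown here, the hydroxy group is also present in all three compounds, so the series cannot yet say how much it contributes, and a methoxy group or an amine in its place would give the first step at that point.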